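Amine chain variants and an outlook for compound 4

The source may report more compounds than this note shows. Statements on the series, on what has been measured and on what is new or still open speak of the compounds shown alone.

Compound 1 `CC(C)=CCc1cc(C(=O)Nc2cc3ccc(OCCC4CCCCN4)c(C)c3oc2=O)ccc1O`: 710 nM
Compound 2 `CC(C)=CCc1cc(C(=O)Nc2cc3ccc(OCC4CCCN(C)C4)c(C)c3oc2=O)ccc1O`: 2640 nM
Compound 3 `CCCNCCCOc1ccc2cc(NC(=O)c3ccc(O)c(CC=C(C)C)c3)c(=O)oc2c1C`: 980 nM

All three numbers come from a functional assay on MCF7 cells (Homo sapiens) for antiproliferative activity; on this read-out higher numbers stand for weaker inhibition and lower numbers for stronger inhibition. Compound 3 stands second highest of the three; its gap to compound 1 is within the scatter, a 1.4-fold higher number from compound 1 to compound 3 (0.14 log units; within the scatter), whereas compound 2 sits further off, a 2.7-fold lower number from compound 2 to compound 3 (0.43 log units; beyond the scatter). Compound 4 `CC(C)=CCc1cc(C(=O)Nc2cc3ccc(OCCCN(C)Cc4ccccc4)c(C)c3oc2=O)ccc1O` carries benzyl(methyl)amino in place of propylamino on a saturated chain carbon, three bonds along the chain from an oxygen on an aromatic ring. Among the measured compounds shown here, no measured step covers this exact change; the nearest reference is a 3.7-fold higher number from compound 1 to compound 2 (0.57 log units; beyond the scatter), in which the group without a hydrogen-bond donor gave the higher number. The entering group here likewise has no hydrogen-bond donor and is larger. The step expected in this assay is a modestly higher number, a 1.6-fold higher number from compound 3 to compound 4 (0.21 log units; within the scatter). Compound 4 is therefore estimated at 1600 nM, range 500 nM to 5000 nM.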

Compound 4, half-maximal inhibitory concentration: 11500 nM
Compound 4: the middle estimate sits 7.2-fold (0.86 log units) below what was measured; measured number above the stated range.
By their numbers in this assay, from the lowest: compounds 1 and 3 (each within the scatter of the next); then compound 2; then compound 4.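

In this assay, among the compounds shown here, benzyl(methyl)amino in place of propylamino, three bonds along the chain from an oxygen on an aromatic ring, gives a 12-fold higher number from compound 3 to compound 4 (1.07 log units; beyond the scatter) and so a larger step than any among the earlier compounds. Compound 2 also has no hydrogen-bond donor in this group, yet a 4.4-fold higher number from compound 2 to compound 4 (0.64 log units; beyond the scatter) still separates the two, and a 16-fold higher number from compound 1 to compound 4 (1.21 log units; beyond the scatter) is the widest gap among the four compounds. The compounds shown leave open whether the benzyl group or the methyl on nitrogen carries the step; benzylamino and methyl(propyl)amino would separate the two. No measurement here accounts for the size of these steps.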